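The compounds below may be only part of what the source reports. "The series", "measured", "known", "first", "only" and "open" are said of these compounds alone.

Measured compounds:
compound 1, `Cc1cc(N2CC[C@@H](C)[C@@H](N(C)c3ncnc4[nH]ccc34)C2)n2nc(SCc3ccccc3)nc2n1`, 13900 nM
compound 2, `Cc1cc(N2CC[C@@H](C)[C@@H](N(C)c3ncnc4[nH]ccc34)C2)n2nc(SCc3ccc(Cl)cc3)nc2n1`, 18400 nM
compound 3, `Cc1cc(N2CC[C@@H](C)[C@@H](N(C)c3ncnc4[nH]ccc34)C2)n2nc(SCc3ccc(C(F)(F)F)cc3)nc2n1`, 9540 nM

All three were read in a functional assay on HGC-27 cells (Homo sapiens) for inhibition, read by MTT assay, with a stated time of 72 h; a higher number here means a weaker inhibitor, a lower number a stronger inhibitor. Compound 2 gives 18400 nM there, and its number sits within the scatter of both neighbours: the step of a 1.3-fold higher number from compound 1 to compound 2 (0.12 log units; within the scatter) and the step of a 1.9-fold lower number from compound 2 to compound 3 (0.29 log units; within the scatter) are each within the usual spread, as is a 1.5-fold lower number from compound 1 to compound 3 (0.16 log units; within the scatter). No compound can therefore be called the stronger or weaker inhibitor among these three.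

Compound 4, `Cc1cc(N2CC[C@@H](C)[C@@H](N(C)c3ncnc4[nH]ccc34)C2)n2nc(SCCCc3ccccc3)nc2n1`, has not yet been measured. It differs from compound 2 in one place: phenethyl in place of 4-chlorophenyl on a saturated chain carbon bound to a sulfur. Within the data shown here, none of the measured steps alters the chain between the sulfur and the aromatic ring; they only exchange a hydrogen, a chloro or a trifluoromethyl on that ring, and each of them stayed within the scatter. There is thus no measured step that bears directly on a longer chain, and the known steps give no reason to expect a move beyond the scatter.

Compound 4 is therefore expected to give about 14000 nM in this assay, in a range from 5000 nM to 40000 nM, an expected step of a 1.3-fold lower number from compound 2 to compound 4 (0.12 log units; within the scatter).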

Compound 4, half-maximal inhibitory concentration: > 100000 nM
Compound 4 was reported as a limit; the forecaster's own chance of this, stated with the estimate: 10%; middle value at least 7.1-fold (0.85 log units) from the limit.
By their numbers in this assay, from the lowest: compounds 3, 1 and 2 (each within the scatter of the next). At a limit, above all of these: compound 4.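

In this assay, the length of the chain between the sulfur and the aromatic ring proves to be a sensitive feature, which the exchanges of hydrogen, chloro and trifluoromethyl on that ring could not show, since each of them stayed within the scatter. Going from benzyl to 3-phenylpropyl on the sulfur gives an at least 7.1-fold higher number from compound 1 to compound 4 (0.85 log units; beyond the scatter), and the same change from the substituted rings gives an at least 5.4-fold higher number from compound 2 to compound 4 (0.73 log units; beyond the scatter) and an at least 10-fold higher number from compound 3 to compound 4 (1.02 log units; beyond the scatter). The value of compound 4 is a limit and not a number: the limit of > 100000 nM in this assay, at which 1 of the 4 values shown sits.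

The compounds shown leave open where along the chain the loss sets in, as 2-phenylethyl on the sulfur is not among them. They also leave open whether an amine or a carboxylic acid on the aromatic ring would move the number beyond the scatter.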